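This account rests on a few compounds, and the source may have more. Where it says the series, first, only, none or still open, it means among the compounds named here.

Working notes on the cytotoxicity series. Compound 1 `COC(=O)C1C(=O)C(C(=O)OC)[C@H](c2ccccn2)N(Cc2ccccc2)[C@@H]1c1ccccn1` carries a phenyl on a saturated chain carbon bound to an amine nitrogen in a ring; in an ADME assay on J774.1 cells (Mus musculus) for cytotoxicity, with a stated time of 48 h (a higher number here means that more compound is needed for the effect, a lower number that less compound is needed), compound 1 gives 34 uM. Compound 3 `COC(=O)C1C(=O)C(C(=O)OC)[C@H](c2ccccn2)N(CCCO)[C@@H]1c1ccccn1` carries 2-hydroxyethyl in that place, and in this assay compound 3 gives 32 uM. For the measured compounds named here, the step of a 1.1-fold lower number from compound 1 to compound 3 (0.03 log units; within the scatter) is the only measured step in the set and lies within the scatter.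

Compound 2 `C[C@@H]1CC2(C[C@H](C)N1)C(=O)N(CCO)C(=O)N2Cc1ccccc1` has a different core. In this assay compound 2 gives > 100 uM, which is a limit of the assay and not a number (the limit of > 100 uM in this assay, at which 1 of the 3 values shown sits).

Compound 4 `C[C@@H]1CC2(C[C@H](C)N1)C(=O)N(Cc1ccc([N+](=O)[O-])cc1)C(=O)N2Cc1ccccc1` differs from compound 2 by 4-nitrophenyl in place of hydroxymethyl on a saturated chain carbon bound to an amide-type nitrogen in a ring. Going by the values given here, no measured step shares this core or a saturated chain carbon bound to an amide-type nitrogen in a ring. Among the compounds with values here, the nearest comparison is the one measured exchange between 2-hydroxyethyl and phenyl, a 1.1-fold lower number from compound 1 to compound 3 (0.03 log units; within the scatter), which stayed within the scatter. On that ground no step beyond the scatter is expected in this assay for compound 4. Compound 2 stands at a limit, so a limit is again the most likely report for compound 4. The estimate for compound 4 in this assay is 100 uM, with a range from 40 uM to 300 uM, meaning an expected step of a number no higher from compound 2 to compound 4 (the limit leaves the size open).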

Compound 4, concentration for half-maximal effect: 42.4 uM
Compound 4: the middle estimate sits 2.4-fold (0.37 log units) above what was measured; the range from low to high includes it.
By their numbers in this assay, from the lowest: compounds 3, 1 and 4 (each within the scatter of the next). At a limit, above all of these: compound 2.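

In this assay, for the compounds shown here, 4-nitrophenyl in place of hydroxymethyl on a saturated chain carbon bound to an amide-type nitrogen in a ring gives an at least 2.3-fold lower number from compound 2 to compound 4 (0.37 log units; beyond the scatter), the first step in the set that lies beyond the scatter. The earlier exchange, on a saturated chain carbon bound to an amine nitrogen in a ring and on a different core, gave a 1.1-fold lower number from compound 1 to compound 3 (0.03 log units; within the scatter), so the two steps differ in both place and core and cannot be assigned to either one alone. Compound 2 stands at a limit of the assay and not at a number, so only the lower bound of the new step's size can be read: the limit of > 100 uM in this assay, at which 1 of the 4 values shown sits.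

Open, from the compounds shown here alone, is which part of 4-nitrophenyl goes with the step, the aromatic ring or the nitro group: an amine in place of the nitro group, or a longer chain ending in a carboxylic acid in place of hydroxymethyl, would bear on that. Going by these compounds alone, also open is whether a change at this place would act the same way in other members, since this core offers only one step.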